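Replacing the amidine of compound 3 with isopropylamino

The source may report more compounds than this note shows. Statements on the series, on what has been measured and on what is new or still open speak of the compounds shown alone.

Measured compounds:
compound 1 `CCCc1nc2c(OCc3ccccc3)cccn2c1N` gives 31%
compound 2 `Cc1nc2c(OCc3ccc(Cl)cc3)cccn2c1N` gives 66%
compound 3 `Cc1nc2c(OCc3ccccc3)cccn2c1/N=C/N(C)C` gives 64%

In a functional assay on the whole organism with Rattus norvegicus as the target, at a dose of 40 mg/kg by the intraperitoneal route (on this read-out higher numbers stand for more inhibition at the one dose given (going by the name of the read-out) and lower numbers for less inhibition), compound 3 stands second highest of the three numbers. Its nearest neighbour is compound 2, whose value lies within the scatter of that of compound 3, so no order between them can be claimed. Compound 1 lies well below, beyond the scatter. Compound 4 `Cc1nc2c(OCc3ccccc3)cccn2c1NC(C)C` has not yet been measured. Among the measured compounds shown here, it differs from compound 3 in one place: a group of 4 heavy atoms (3 carbon, 1 nitrogen; no ring) in place of a group of 5 heavy atoms (3 carbon, 2 nitrogen; no ring), on an aromatic carbon There is no measured pair with the same change, so the size of the step is open. The account expects a modest fall in this assay for compound 4, estimated at 52% (range 25% to 75%), corresponding to an expected step of a number 12 percentage points lower from compound 3 to compound 4 (beyond the scatter).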

Compound 4, a percentage reported as inhibition, in the whole organism at one dose (the size of the read-out at that dose, not a potency): 18%
Estimate against measurement, compound 4: 34 percentage points above, outside the stated range (below it).
By their numbers in this assay, from the lowest: compound 4; then compound 1; then compounds 3 and 2 (each within the scatter of the next).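

In this assay, the group on this aromatic carbon proves decisive: isopropylamino in place of the amidine gives a number 46 percentage points lower from compound 3 to compound 4 (beyond the scatter), a large step. Among the compounds shown here, the earlier compounds offered no pair differing at this place alone, so this is the first direct reading of a change there. Nothing available explains the size of this step.

The compounds shown leave open how dimethylamino or acetamido on this carbon would read on the core of compound 3. They also leave open whether the same change would give a similar step on the core of compound 2.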